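Hydroxamate tail swap on an imidazoline Mdm2 inhibitor

This account rests on a few compounds, and the source may have more. Where it says the series, first, only, none or still open, it means among the compounds named here.

Measured so far:
compound 1, `CCOc1cc(C(C)(C)C)ccc1C1=NC(c2ccc(Cl)cc2)C(c2ccc(Cl)cc2)N1C(=O)N1CCN(CCCCCCCC(=O)NO)CC1`: 290 nM
compound 2, `CCOc1cc(C(C)(C)C)ccc1C1=NC(c2ccc(Cl)cc2)C(c2ccc(Cl)cc2)N1C(=O)N1CCC(C(=O)Nc2ccc(/C=C/C(=O)NO)cc2)CC1`: 2650 nM

Both compounds were tested in an assay on isolated protein for inhibition of E3 ubiquitin-protein ligase Mdm2 (Homo sapiens), read by fluorescence polarization, with a stated time of 30 min; a higher number here means a weaker inhibitor, a lower number a stronger inhibitor. Compound 1 has the lower of the two numbers; compound 2 stands above it by a gap that is beyond the usual scatter. The shared core is kept throughout, and the compounds differ only in the group on the urea-linked ring.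

Compound 3, `CCOc1cc(C(C)(C)C)ccc1C1=NC(c2ccc(Cl)cc2)C(c2ccc(Cl)cc2)N1C(=O)N1CCN(c2ncc(C(=O)NO)cn2)CC1`, has not yet been measured. Relative to compound 1 the change is 5-(hydroxycarbamoyl)pyrimidin-2-yl in place of 7-(hydroxycarbamoyl)heptyl on an amine nitrogen in a ring. Among the measured compounds shown here, no measured pair shows this exact exchange, so the expected step rests on the two values alone: compound 2, with a rigid aryl hydroxamate, is weaker than compound 1 with its chain, and the pyrimidinyl group of compound 3 is likewise short and rigid. A modest loss, possibly within the scatter, is expected, so that the step from compound 1 to compound 3 is estimated as a 2.1-fold higher number from compound 1 to compound 3 (0.32 log units; beyond the scatter). For compound 3 the estimate in this assay is 600 nM, between 200 nM and 2000 nM.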

Compound 3, inhibition constant: 1050 nM
The estimate for compound 3 lay 1.8-fold (0.24 log units) below the measured number; the range from low to high includes it.
By their numbers in this assay, from the lowest: compound 1; then compound 3; then compound 2.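

In this assay, among the compounds shown here, the exchange of 7-(hydroxycarbamoyl)heptyl for 5-(hydroxycarbamoyl)pyrimidin-2-yl on an amine nitrogen in a ring gives a 3.6-fold higher number from compound 1 to compound 3 (0.56 log units; beyond the scatter) as the first reading of a single exchange at this place. It shows that the open chain at this position can give way to a six-membered aromatic ring with a modest loss that is still beyond the scatter. Nothing measured here accounts for this step.

The compounds shown leave open how a shorter or longer chain ending in the hydroxamate would read on the same nitrogen, and whether a phenyl ring in place of the pyrimidine would read differently. They also leave open whether a carboxylic acid could stand in for the hydroxamate on either group.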